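Fluorinated biaryl indazoles as TRPA1 antagonists: working notes

This account rests on a few compounds, and the source may have more. Where it says the series, first, only, none or still open, it means among the compounds named here.

In an assay on CHO-TREX cells for antagonist activity at transient receptor potential cation channel subfamily A member 1 (Homo sapiens), read by FLIPR and calcium flux, with a stated time of 10 min (on this read-out higher numbers stand for weaker inhibition and lower numbers for stronger inhibition), compound 1 `c1ccc(-c2ccc3[nH]ncc3c2)cc1` gives > 30000 nM, which is a limit of the assay rather than a number, as marked by the limit of > 30000 nM in this assay, at which 1 of the 3 values shown sits. Compound 2 `Fc1ccccc1-c1ccc2[nH]ncc2c1` gives 3950 nM; the change fluoro in place of hydrogen on an aromatic carbon yields an at least 7.5-fold lower number from compound 1 to compound 2 (0.88 log units; beyond the scatter). Compound 3 `FC(F)(F)c1ccccc1-c1ccc2[nH]ncc2c1` gives 164 nM in this assay ; the change trifluoromethyl in place of hydrogen on an aromatic carbon yields an at least 180-fold lower number from compound 1 to compound 3 (2.26 log units; beyond the scatter), and against compound 2 the change is a 24-fold lower number from compound 2 to compound 3 (1.38 log units; beyond the scatter).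

Compound 4 `Fc1cc2[nH]ncc2cc1-c1ccccc1C(F)(F)F` is unmeasured. It differs from compound 3 by fluoro in place of hydrogen on an aromatic carbon, the same kind of change as that from compound 1 to compound 2, though not the same: there the fluoro entered on a six-membered aromatic ring of carbon only, ortho to a group of 9 heavy atoms, whereas here it enters on a ring that is part of a fused or bridged system of two rings, ortho to a large group, meta to a fused ring and para to a fused ring. The two cores differ by trifluoromethyl in place of hydrogen on an aromatic carbon.

The measured fluoro step rests on a limit, so its true size is open. A smaller step is expected from compound 3 to compound 4, a 1.8-fold lower number from compound 3 to compound 4 (0.26 log units; within the scatter), because the measured fluoro step an at least 7.5-fold lower number from compound 1 to compound 2 (0.88 log units; beyond the scatter) rests on a limit and here the fluoro enters on a different place. Compound 4 is estimated at 90 nM in this assay , between 25 nM and 350 nM.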

Compound 4, half-maximal inhibitory concentration: 48 nM
Compound 4: middle estimate off by 1.9-fold (0.27 log units), on the high side; the range from low to high includes it.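

Fluoro in place of hydrogen on an aromatic carbon again lowers the number in this assay, with a 3.4-fold lower number from compound 3 to compound 4 (0.53 log units; beyond the scatter). On these two cores the change points the same way, even though the fluoro enters at a different place on each, but two cores do not make a general rule, and the size of the step cannot be said to carry over: the same change on two cores in this assay, an at least 7.5-fold lower number (0.88 log units; beyond the scatter) from compound 1 to compound 2 and a 3.4-fold lower number (0.53 log units; beyond the scatter) from compound 3 to compound 4; the limit leaves it open whether they differ. The value of compound 1 is a limit of the assay and not a number: the limit of > 30000 nM in this assay, at which 1 of the 4 values shown sits.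

The compounds shown leave open whether the step on the fused ring of compound 4 depends on the trifluoromethyl group on the other ring, since the same fluoro on the fused ring of the core of compound 1 is not among them. They also leave open how a chloro, a nitrile, a methoxy group or an amine would compare with the fluoro of compound 4 at that place.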